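Removing one methoxy group from compound 3

The source may report more compounds than this note shows. Statements on the series, on what has been measured and on what is new or still open speak of the compounds shown alone.

Compound 1 `O=C1CCc2cc(-c3csc(-c4cccnc4)n3)ccc2N1`: 1000 nM
Compound 2 `O=C1CCc2cc(-c3csc(-c4ccccc4)n3)ccc2N1`: > 10000 nM (a limit of the assay)
Compound 3 `COc1ccc(-c2nc(-c3ccc4c(c3)CCC(=O)N4)cs2)cc1OC`: 300 nM

In a functional assay for inhibition, with Homo sapiens as the target (a higher number here means a weaker inhibitor, a lower number a stronger inhibitor), compound 3 gives 300 nM, the lowest number here. It lies beyond the scatter from its nearest neighbour, compound 1 at 1000 nM.

Compound 4 `COc1ccc(-c2nc(-c3ccc4c(c3)CCC(=O)N4)cs2)cc1` has not been measured. It carries hydrogen in place of methoxy on an aromatic carbon, ortho to a methoxy group and meta to a large group: hydrogen in place of methoxy on an aromatic carbon.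

Within the data shown here, no measured step makes this exact change. The closest guide is an at least 10-fold higher number from compound 1 to compound 2 (1.00 log units; beyond the scatter), where phenyl replaces pyridin-3-yl, and it shows that a change on this outer ring can matter greatly. Compound 2, whose phenyl carries no methoxy, reaches only > 10000 nM, which is a limit and not a number. Compound 4 keeps one methoxy, so a clear move toward weaker inhibition is expected, though probably not all the way to that limit.

The expected change is a 4.0-fold higher number from compound 3 to compound 4 (0.60 log units; beyond the scatter). For compound 4 the estimated value is 1200 nM, with an expected range from 350 nM to 5000 nM.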

Compound 4, half-maximal inhibitory concentration: 9000 nM
For compound 4 the middle estimate is 7.5-fold (0.88 log units) below the measured one; measured number outside the range, above it.
By their numbers in this assay, from the lowest: compound 3; then compound 1; then compound 4. At a limit, above all of these: compound 2.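

This position carries much of the strength of compound 3 in this assay, and the change is large: a 30-fold higher number from compound 3 to compound 4 (1.48 log units; beyond the scatter), so the one methoxy left on the ring does not hold that strength on its own. Keeping that single methoxy also does not match the pyridin-3-yl ring, with a 9.0-fold higher number from compound 1 to compound 4 (0.95 log units; beyond the scatter). Against the phenyl ring without a methoxy, the single methoxy gives an at least 1.1-fold lower number from compound 2 to compound 4 (0.04 log units; that floor lies within the scatter), so no clear gain from it can be claimed. Compound 2 stands at a limit of the assay and not at a number: the limit of > 10000 nM in this assay, at which 1 of the 4 values shown sits.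

The compounds shown leave open whether this position needs a methoxy in particular, or whether a hydroxyl or an amine there would serve as well. Also open, from the compounds shown here alone, is what would happen if the other methoxy of compound 3 were the one replaced by hydrogen.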